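Amide to urea on the piperidine nitrogen of compound 2

The source may hold more compounds than are shown below. What is called first, only, known or untested is meant among the compounds shown, and "the series" means these compounds.

Two compounds of this series carry numbers in an assay on L1.2 cells for binding affinity to C-C chemokine receptor type 8 (Homo sapiens); a higher number here means a weaker inhibitor, a lower number a stronger inhibitor. Compound 1 `O=C(Nc1ccc(S(=O)(=O)N2CCOCC2)c2ccccc12)c1ccccc1` gives 7750 nM. Compound 2 `COCC(=O)N1CCC(NS(=O)(=O)c2ccc(NC(=O)c3ccccc3C)c3ccccc23)CC1` gives 15.8 nM, the lower of the two numbers and far beyond the scatter away from compound 1, so compound 2 stands as the stronger inhibitor of the pair. Among the compounds with values here, no step between measured compounds that differ in one place has been worked out, so the gap between compound 1 and compound 2 carries no further reading.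

Compound 3 `Cc1ccccc1C(=O)Nc1ccc(S(=O)(=O)NC2CCN(C(=O)N(C)C)CC2)c2ccccc12` is the next member, not yet measured in this assay. It differs from compound 2 in one place: dimethylamino in place of methoxymethyl on a carbonyl carbon. The exchange sits on a carbonyl carbon whose other neighbour is an amide-type nitrogen in a ring; the rest of compound 2 is untouched. Within the data shown here, no measured step of this kind exists, so the expectation rests on the value of compound 2 alone. The estimated step of a 1.3-fold higher number from compound 2 to compound 3 (0.10 log units; within the scatter) is expected to stay within the scatter, with no clear direction. Compound 3 is accordingly expected to give 20 nM, in the range 6 nM to 65 nM.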

Compound 3, inhibition constant: 1.6 nM
Compound 3: middle estimate off by 13-fold (1.10 log units), on the high side; measured number below the stated range.
By their numbers in this assay, from the lowest: compound 3; then compound 2; then compound 1.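

In this assay, the change from (methoxymethyl)carbonyl to dimethylcarbamoyl gives a 9.9-fold lower number from compound 2 to compound 3 (0.99 log units; beyond the scatter), so this position, on a carbonyl carbon whose other neighbour is an amide-type nitrogen in a ring, responds to a single exchange. The group that leaves and the group that enters both count 3 heavy atoms with no ring and no hydrogen-bond donor, so a step of this size does not need a change in heavy-atom count; what differs in the counts is nitrogen for carbon and oxygen, and 0 hydrogen-bond acceptors for 1. No measurement on hand accounts for the step, so its origin stays unassigned.

A single pair cannot show whether the lower number belongs to dimethylamino in particular or extends to other groups joined through nitrogen at this carbonyl carbon, and compound 1 differs from the other two in more than one place, so it adds no reading here. Diethylamino, a pyrrolidine ring bound through its nitrogen, or a methoxy group on the same carbonyl carbon would show how far the trend reaches.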